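Working notes: cytotoxicity across four related analogues

This account rests on a few compounds, and the source may have more. Where it says the series, first, only, none or still open, it means among the compounds named here.

Measured so far in an ADME assay on Huh-7 cells (Homo sapiens) for cytotoxicity, with a stated time of 3 days; on this read-out higher numbers stand for lower toxicity in this test and lower numbers for higher toxicity in this test:
Compound 1, `COc1ccccc1NC(=O)c1c(NO)cc(-c2ccccc2)oc1=O`, gives > 20000 nM, a limit of the assay rather than a number.
Compound 2, `CCOc1ccccc1NC(=O)c1c(NO)cc(-c2ccccc2)oc1=O`, gives > 20000 nM, likewise a limit of the assay.
Compound 3, `COc1ccccc1NC(=O)c1c(NCCO)cc(-c2cccc(Br)c2)oc1=O`, gives > 20000 nM, again a limit of the assay.

The first pair share a core; compound 2 differs from compound 1 by methyl in place of hydrogen on a saturated chain carbon bound to an oxygen on an aromatic ring. In this assay the step that the two limits leave unreadable from compound 1 to compound 2 is therefore not readable as a size, since both ends are limits. Among the compounds with values here, all that the measured values show is the limit of > 20000 nM in this assay, at which 3 of the 3 values shown sit, so no step within the measured set is resolved at all.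

Compound 3 rests on a core that differs from that of compound 1 in more than one place; the difference between the two cores is not broken down here.

Compound 4, `CCOc1ccccc1NC(=O)c1c(NCCO)cc(-c2cccc(Br)c2)oc1=O`, is not yet measured. It differs from compound 3 by methyl in place of hydrogen on a saturated chain carbon bound to an oxygen on an aromatic ring, the same change as that from compound 1 to compound 2, at the same place. Within the data shown here, the only guide is that compound 1 and compound 2 both sit at the limit of this assay, and compound 3 sits there too. On that basis the step that the limit leaves unreadable from compound 3 to compound 4 is expected to be small, with compound 4 most likely again reported only as a limit. The estimate for compound 4 in this assay is 30000 nM, within 15000 nM to 100000 nM.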

Compound 4, half-maximal cytotoxic concentration: > 20000 nM
Compound 4 was reported as a limit; the forecaster's own chance of this, stated with the estimate: 85%; the middle value is on the limit's open side.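

No step can be read from compound 3 to compound 4 in this assay, since both compounds are reported only as limits of the assay, as is the whole set: the limit of > 20000 nM in this assay, at which 4 of the 4 values shown sit.

The compounds shown leave open whether methoxy to ethoxy changes cytotoxicity at all, and at what concentration any of these four compounds would turn toxic to these cells.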